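Swapping a sulfur chain for butylamino on the shared core

The source may report more compounds than this note shows. Statements on the series, on what has been measured and on what is new or still open speak of the compounds shown alone.

In an ADME assay on Akata cells (Homo sapiens) for cytotoxicity, with a stated time of 7 days (on this read-out lower numbers stand for higher toxicity in this test and higher numbers for lower toxicity in this test), compound 1 `CSc1nc(N)nc2c1ncn2/C=C1/CC1(CO)CO` reads > 20000 nM, which is a limit and not a number. Compound 2 `CCCCCCSc1nc(N)nc2c1ncn2/C=C1/CC1(CO)CO` reads > 20000 nM, again a limit. Compound 3 `CC(C)Sc1nc(N)nc2c1ncn2/C=C1/CC1(CO)CO` reads > 20000 nM, also a limit. It therefore stands with the other two, at the limit of > 20000 nM in this assay, at which 3 of the 3 values shown sit.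

The next compound, compound 4 `CCCCNc1nc(N)nc2c1ncn2/C=C1/CC1(CO)CO`, carries butylamino in place of isopropylsulfanyl on an aromatic carbon.

Three measured steps are the nearest guide, and all of them alter only the chain on the sulfur: a step that the two limits leave unreadable from compound 1 to compound 2, a step that the two limits leave unreadable from compound 1 to compound 3 and a step that the two limits leave unreadable from compound 2 to compound 3. None gives a readable size, and none replaces the sulfur-linked group with butylamino. The expectation is thus no clear shift in this assay, though a move towards lower numbers, meaning higher toxicity in this test, cannot be excluded. The expected change is a number no higher from compound 3 to compound 4 (the limit leaves the size open). For compound 4 the estimated value is 20000 nM, with an expected range from 6000 nM to 60000 nM.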

Compound 4, half-maximal cytotoxic concentration: > 24000 nM
Compound 4: no number, only a limit; the forecaster's own chance of this, stated with the estimate: 70%; at least 1.2-fold (0.07 log units) between middle value and limit.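

In this assay compound 4 gives > 24000 nM, which is a limit. All four values are limits, so the steps to compound 4 from compound 1, compound 2 and compound 3 cannot be read. The compounds shown leave open whether exchanging these sulfur-linked chains or butylamino on the shared core changes the read-out at all.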